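This account rests on a few compounds, and the source may have more. Where it says the series, first, only, none or still open, it means among the compounds named here.

Of the compounds shown here, two have numbers so far. Compound 1 (`COc1cc(C)cc(-c2c(-c3ccnc(-c4ccc(C(C)=O)cc4)c3)cnn2CC#N)c1`) carries an acetyl on the outer phenyl ring; compound 2 (`COc1cc(C)cc(-c2nn(CC#N)cc2-c2ccc(-c3cccc(C(C)=O)c3)nc2)c1`) carries the same group but on a differently arranged outer ring. In a functional assay on HOP-92 cells (Homo sapiens) for inhibition, read by sulforhodamine B assay, with a stated time of 48 h (on this read-out lower numbers stand for stronger inhibition of growth and higher numbers for weaker inhibition of growth), compound 1 gives 7560 nM, and in this assay compound 2 gives 9090 nM. Compound 1 has the lower of the two numbers, but the gap to compound 2 lies within the usual scatter, so the two read as equivalent and no order between them can be claimed.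

Compound 3 (`COc1cc(C)cc(-c2c(-c3ccnc(-c4ccc(N(C)C)cc4)c3)cnn2CC#N)c1`) is not yet measured. It differs from compound 1 in one place: dimethylamino in place of acetyl on an aromatic carbon. Within the data shown here, no pair of measured compounds in this set differs at that position, so there is nothing to calibrate the step against; the only anchors are the values of compound 1 and compound 2, which sit close together.

For this assay the expected step from compound 1 to compound 3 is a 1.1-fold lower number from compound 1 to compound 3 (0.03 log units; within the scatter), that is, no change beyond the scatter in either direction, with a wide band to reflect the missing precedent. The estimate for compound 3 in this assay is 7000 nM, expected to fall between 2500 nM and 20000 nM.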

Compound 3, concentration for total growth inhibition: 55.3 nM
The estimate for compound 3 lay 130-fold (2.10 log units) above the measured number; measured number outside the range, below it.
By their numbers in this assay, from the lowest: compound 3; then compounds 1 and 2 (each within the scatter of the next).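

Going from 4-acetylphenyl to 4-(dimethylamino)phenyl in this assay gives a 140-fold lower number from compound 1 to compound 3 (2.14 log units; beyond the scatter), which shows that the group on this aromatic carbon, para to a large group, can strongly shift the number for growth inhibition. Compound 1 and compound 2 both carry acetyl, so neither could reveal this sensitivity, and their close values gave no hint of it. Acetyl and dimethylamino match in heavy atoms, hydrogen-bond donors, hydrogen-bond acceptors and net charge, so these counts do not separate the two compounds, and no measurement in hand bears on the reason for the step.

Still open, as far as these compounds go, is whether the shift belongs to dimethylamino itself or extends to other groups at this place, such as a primary amine, a diethylamino group, a morpholine or a methoxy group, since only two substituents can be compared here. Also open, from the compounds shown here alone, is whether dimethylamino would produce a similar shift on the differently arranged outer ring of compound 2, and whether the result holds beyond this assay in other cell lines.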